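This account rests on a few compounds, and the source may have more. Where it says the series, first, only, none or still open, it means among the compounds named here.

Working notes on the series. All three measured compounds share one core and differ in the aryl group on a nitrogen on an aromatic ring or in the aryl group on the urea. In a functional assay on NCI-H520 cells (Homo sapiens) for inhibition, read by MTT assay, with a stated time of 48 h, tested at 10 uM (on this read-out higher numbers stand for more inhibition at the one concentration tested (going by the name of the read-out) and lower numbers for less inhibition), compound 1 `Cc1ccc(Nc2cc(NC(=O)Nc3c(Cl)cccc3Cl)ncn2)cc1C` gives 47.5%. In this assay compound 3 `COc1ccc(Br)cc1Nc1cc(NC(=O)Nc2c(Cl)cccc2Cl)ncn1` gives 45%. In this assay compound 2 `COc1cc(NC(=O)Nc2cc(Nc3ccc(C)c(C)c3)ncn2)cc(OC)c1` gives 29.5%, the lowest of the three numbers, with compound 3 nearest and compound 1 furthest, both beyond the scatter from it.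

Compound 4 `CCc1cccc(Nc2cc(NC(=O)Nc3cc(OC)cc(OC)c3)ncn2)c1` is not yet measured in this assay. It differs from compound 2 by 3-ethylphenyl in place of 3,4-dimethylphenyl on a nitrogen on an aromatic ring, the rest of compound 2 being kept. Among the measured compounds shown here, the only measured step that bears on this is the exchange of the aryl group on the same nitrogen, a number 2.5 percentage points lower from compound 1 to compound 3 (within the scatter), which left the read-out within the scatter. On that basis the change to compound 4 is expected to give a step of a number 0.5 percentage points higher from compound 2 to compound 4 (within the scatter), not beyond the scatter. Compound 4 is estimated at 30%, within a range of 15% to 45%.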

Compound 4, a percentage reported as inhibition, at one concentration (the size of the read-out at that concentration, not a potency): 23%
Compound 4: middle estimate off by 7 percentage points, on the high side, and the stated range covers the measured number.
By their numbers in this assay, from the lowest: compounds 4 and 2 (each within the scatter of the next); then compounds 3 and 1 (each within the scatter of the next).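

In this assay, the exchange of 3,4-dimethylphenyl for 3-ethylphenyl on a nitrogen on an aromatic ring gives a number 6.5 percentage points lower from compound 2 to compound 4 (within the scatter). This adds a second exchange at this nitrogen that stays within the scatter, now with the urea aryl group of compound 2 rather than that of compound 1, and here the two groups have the same atoms, joined differently. Nothing at hand accounts for the size of this step.

As far as these compounds go, both exchanges at this nitrogen keep an aryl group, so it remains open whether a phenyl ring carrying an amine, a carboxylic acid or a longer chain such as propyl would move the read-out beyond the scatter. From the compounds shown here alone, it is also open whether 3-ethylphenyl would behave the same way alongside the urea aryl group of compound 1.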